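The source may hold more compounds than are shown below. What is called first, only, known or untested is meant among the compounds shown, and "the series" means these compounds.

In a functional assay on HL-60 cells (Homo sapiens) for antiproliferative activity, with a stated time of 24 h (on this read-out lower numbers stand for stronger inhibition and higher numbers for weaker inhibition), compound 3 `NC(=O)c1c(NC(=O)c2ccccc2C(F)(F)F)sc2c1CCN(C(=S)Nc1ccccc1Cl)C2` gives 17600 nM, the higher of the two numbers in view. Compound 2 `NC(=O)c1c(NC(=O)c2ccccc2Cl)sc2c1CCN(C(=S)Nc1c(Cl)cccc1Cl)C2` gives 3950 nM, a figure set apart from that of compound 3 by more than the usual scatter. Compound 1 `NC(=O)c1c(NC(=O)c2ccc(C(F)(F)F)cc2)sc2c1CCN(Cc1ccc(Cl)cc1)C2` yields only a limit in this assay, > 50000 nM, and so adds no number to the comparison (the limit of > 50000 nM in this assay, at which 1 of the 3 values shown sits). Compound 4 `NC(=O)c1c(NC(=O)c2ccncn2)sc2c1CCN(C(=S)Nc1ccccc1Cl)C2` differs from compound 3 in a single place: pyrimidin-4-yl in place of 2-(trifluoromethyl)phenyl on a carbonyl carbon. Among the compounds with values here, no measured pair shows this exchange, so the size of its effect is open; a modest weakening or no change beyond the scatter seems the more likely outcome. The step expected here is a 1.3-fold higher number from compound 3 to compound 4 (0.10 log units; within the scatter). Compound 4 is therefore estimated at 22000 nM, within a range from 6000 nM to 50000 nM.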

Compound 4, half-maximal inhibitory concentration: 34600 nM
Beside the measured number, compound 4's estimate is 1.6-fold (0.20 log units) below it, and the stated range covers the measured number.
By their numbers in this assay, from the lowest: compound 2; then compounds 3 and 4 (each within the scatter of the next). At a limit, above all of these: compound 1.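

Within the data shown here, compound 3 and compound 4 form the only measured pair that differs in one place, and in this assay the exchange of 2-(trifluoromethyl)phenyl for pyrimidin-4-yl on a carbonyl carbon gives a 2.0-fold higher number from compound 3 to compound 4 (0.29 log units; within the scatter). A ring of carbon only and a ring with hetero atoms therefore cannot be told apart at this position on this read-out. Nothing measured here gives a cause for this step.

As far as these compounds go, whether a piperidine or an unsubstituted phenyl on this carbonyl carbon would shift the number beyond the scatter remains open. From the compounds shown here alone, it is also open whether the same exchange would give a similar step with a different group elsewhere on the shared core.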